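Amide tail variation and cell cytotoxicity: working notes

The source may hold more compounds than are shown below. What is called first, only, known or untested is meant among the compounds shown, and "the series" means these compounds.

Measured compounds:
compound 1 `Cc1ccc2oc(SCC(=O)Nc3ccc(-c4nc(-c5ccccc5)c(-c5ccccc5)n4C)cc3)nc2c1` gives 22.4 ug/mL in a functional assay on HT-29 cells (Homo sapiens) for cytotoxicity, read by MTT assay, with a stated time of 24 h; a lower number here means a stronger inhibitor, a higher number a weaker inhibitor
compound 2 `Cc1nnc(SCC(=O)Nc2ccc(-c3nc(-c4ccccc4)c(-c4ccccc4)n3C)cc2)s1` gives 2.7 ug/mL in this assay
compound 3 `Cn1ccnc1SCC(=O)Nc1ccc(-c2nc(-c3ccccc3)c(-c3ccccc3)n2C)cc1` gives 47.5 ug/mL in this assay

Compound 3 has the highest number of the three in this assay; its nearest neighbour is compound 1 and its furthest is compound 2, each separated from it by a step beyond the scatter. Among the measured steps, an 8.3-fold lower number from compound 1 to compound 2 (0.92 log units; beyond the scatter) and an 18-fold higher number from compound 2 to compound 3 (1.25 log units; beyond the scatter) are the larger ones, while a 2.1-fold higher number from compound 1 to compound 3 (0.33 log units; beyond the scatter) is modest; all three keep the sulfur and exchange only the heteroaryl on it.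

Compound 4 `CN1CCN(CC(=O)Nc2ccc(-c3nc(-c4ccccc4)c(-c4ccccc4)n3C)cc2)CC1` carries 4-methylpiperazin-1-yl in place of (1-methyl-1H-imidazol-2-yl)sulfanyl on a saturated chain carbon bound to a carbonyl carbon. Among the compounds with values here, none of the measured steps removes the sulfanyl linkage or introduces a non-aromatic ring, so no measured step bears directly on this change; the measured steps only show that tail replacements in this position move the number by modest to large amounts in either direction. Within the data shown here, with no guiding step, the number for compound 4 is expected near that of compound 3, with a wide range, and the step of a 1.4-fold lower number from compound 3 to compound 4 (0.13 log units; within the scatter) is estimated not to exceed the scatter. Compound 4 is expected to give 35 ug/mL in this assay, within 10 ug/mL to 120 ug/mL.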

Compound 4, half-maximal inhibitory concentration: 35.5 ug/mL
Estimate against measurement, compound 4: 1.0-fold (0.01 log units) below, within the range that was stated.
By their numbers in this assay, from the lowest: compound 2; then compounds 1, 4 and 3 (each within the scatter of the next, the first and the last beyond it).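

In this assay the change to 4-methylpiperazin-1-yl on a saturated chain carbon bound to a carbonyl carbon gives a 1.3-fold lower number from compound 3 to compound 4 (0.13 log units; within the scatter) and a 1.6-fold higher number from compound 1 to compound 4 (0.20 log units; within the scatter), so a tail with a non-aromatic ring and no sulfur cannot be told apart from these two sulfanyl tails. Only the (5-methyl-1,3,4-thiadiazol-2-yl)sulfanyl tail stands apart, with a 13-fold higher number from compound 2 to compound 4 (1.12 log units; beyond the scatter), which shows that the low number of compound 2 does not carry over to the 4-methylpiperazin-1-yl tail. No available evidence accounts for these differences.

From the compounds shown here alone, whether a morpholine or a dimethylamino group in this place would stay with compound 4 or move towards compound 2 remains open. Also open, going by these compounds, is whether a longer chain between the carbonyl and the 4-methylpiperazin-1-yl group would change the number.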